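From 4-bromophenyl to 5-methyl-1,2-oxazol-3-yl on the amide

A few compounds are considered here, and "the series" means these few. Any claim that something is new, unique, unknown or untested is made for them only; others in the source may bear on it.

Going by the values given here, only two compounds have been measured so far. In a functional assay on CCRF-CEM cells (Homo sapiens) for cytotoxicity, read by propidium iodide staining, with a stated time of 48 h (a lower number here means that less compound is tolerated, a higher number that more compound is tolerated), compound 1 (`O=C(CN1C(=O)S/C(=C/c2ccco2)C1=O)Nc1ccc(Br)cc1`) gives 81000 nM and compound 2 (`O=C(CN1C(=O)S/C(=C/c2ccco2)C1=O)Nc1ccc(Cl)cc1C(F)(F)F`) gives 79900 nM and these two numbers lie within the usual scatter of each other. Compound 1 therefore stands level with compound 2, and neither can be ranked above the other.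

The next compound to be tested is compound 3 (`Cc1cc(NC(=O)CN2C(=O)S/C(=C/c3ccco3)C2=O)no1`), which keeps the shared core but carries 5-methyl-1,2-oxazol-3-yl in place of 4-bromophenyl on an amide-type nitrogen. Among the compounds with values here, no pair of measured compounds differs in one place only, so the data give no direct guide to the size of such a change. The starting point for a guess is simply compound 1 at 81000 nM in this assay and a modest move towards a higher number is expected, with little confidence in its direction. The expected size of the change is a 1.2-fold higher number from compound 1 to compound 3 (0.09 log units; within the scatter) and it may not exceed the scatter by much. Compound 3 is estimated at 100000 nM with an expected range from 40000 nM to 250000 nM for a measurement still to come.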

Compound 3, half-maximal cytotoxic concentration: > 100000 nM
Compound 3 ended at the assay's limit (the forecaster's own chance of this, stated with the estimate: 25%); the middle value sits exactly at the limit.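

In this assay compound 3 gives > 100000 nM, which is a limit of the assay and not a number. Going by these compounds alone, this is the first change in one place on the amide-type nitrogen, and 5-methyl-1,2-oxazol-3-yl in place of 4-bromophenyl gives an at least 1.2-fold higher number from compound 1 to compound 3 (0.09 log units; that floor lies within the scatter), so a six-membered aromatic ring of carbon only can give way here to a five-membered aromatic ring with 2 hetero atoms without any sign of a lower number in this assay. Only a floor can be given for this step, and its true size stays hidden, because the reading stops at the top of the assay's range: the limit of > 100000 nM in this assay, at which 1 of the 3 values shown sits.

From the compounds shown here alone, whether a simple pyridine ring, a carboxylic acid or a longer alkyl chain on the amide-type nitrogen would move the number in either direction remains open. Going by these compounds, it also remains unknown whether the true gap from compound 1 to compound 3 goes beyond the usual scatter, or whether it is as small as its floor.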